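The compounds below may be only part of what the source reports. "The series", "measured", "known", "first", "only" and "open" are said of these compounds alone.

Measured so far:
- Compound 1, `CC(C)c1ccc(C(=O)N(Cc2ccc(C(=O)NO)cc2)C(C)(C)C(=O)NC2CCCCC2)cc1`: 270 nM
- Compound 2, `Cc1cc(C)cc(C(=O)N(CC(=O)N(C)C)Cc2ccc(C(=O)NO)cc2)c1`: 230 nM
- Compound 3, `Cc1ccc(C(=O)N(CC(=O)NCc2ccccc2)Cc2ccc(C(=O)NO)cc2)c(C)c1`: 60 nM

All three were tested in an assay on Sf9 cells for inhibition of protein deacetylase HDAC6 (Homo sapiens), read by fluorescence, with a stated time of 90 min; a lower number here means a stronger inhibitor, a higher number a weaker inhibitor. Compound 2 gives 230 nM, which is the second highest of the three numbers. Compound 1 gives 270 nM, a number so close to that of compound 2 that the two cannot be told apart by this assay. Compound 3 gives 60 nM, a clearly lower number than that of compound 2, so compound 3 is the stronger inhibitor of the pair.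

Compound 4, `Cc1cc(C)cc(C(=O)N(CC(=O)N2CCCCC2)Cc2ccc(C(=O)NO)cc2)c1`, has not yet been measured. It differs from compound 2 in one place: piperidin-1-yl in place of dimethylamino on a carbonyl carbon. Among the compounds with values here, no measured pair shows this particular change, so its effect is unknown from direct evidence. Compound 3 shows that a different, larger amide group in this region of the molecule goes with a lower number than in compound 2, but that pair differs in more than one place, so it gives only a hint. A small step from compound 2 to compound 4, probably toward a lower number, or none beyond the scatter, is expected: a 1.4-fold lower number from compound 2 to compound 4 (0.16 log units; within the scatter). Compound 4 is therefore estimated at 160 nM, within a range from 70 nM to 380 nM.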

Compound 4, half-maximal inhibitory concentration: 130 nM
Beside the measured number, compound 4's estimate is 1.2-fold (0.09 log units) above it; measured number inside the range.
By their numbers in this assay, from the lowest: compound 3; then compounds 4, 2 and 1 (each within the scatter of the next, the first and the last beyond it).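

In this assay, within the data shown here, putting piperidin-1-yl in place of dimethylamino on a carbonyl carbon gives a 1.8-fold lower number from compound 2 to compound 4 (0.25 log units; within the scatter) and is the first direct reading of a change at this position. It shows that, in this pair, an open dimethylamino group can give way to a six-membered non-aromatic ring without a step beyond the scatter, so the assay cannot separate the two compounds. No measurement is available that would explain this result.

As far as these compounds go, it remains open whether a smaller ring such as pyrrolidin-1-yl, or a ring with a second hetero atom such as morpholin-4-yl, would also stay within the scatter of compound 2. A single pair also leaves open whether the same swap would give a similar step on a different core.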